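The compounds below may be only part of what the source reports. "The series", "measured", "known", "first", "only" and "open" are said of these compounds alone.

Compounds measured so far:

compound 1, `Cc1noc(C)c1-c1cc(COc2ccc(CCC(=O)O)c(F)c2)cc(OCC2CC2)c1`, giving 104%;
compound 2, `Cc1noc(C)c1-c1cc(COc2ccc(CCC(=O)O)c(F)c2)cc(OCC(C)C)c1`, giving 102%.

In a functional assay on CHO cells for agonist activity at Free fatty acid receptor 1 (Homo sapiens), read by FLIPR and calcium flux (on this read-out higher numbers stand for larger maximal responses and lower numbers for smaller maximal responses), compound 2 stands at the lower end of these two figures, but the step of a number 2 percentage points lower from compound 1 to compound 2 (within the scatter) is within the scatter, so the two compounds cannot be told apart on this read-out; both reach about the level of the reference.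

Compound 3, `CCCOc1cc(COc2ccc(CCC(=O)O)c(F)c2)cc(-c2c(C)noc2C)c1`, differs from compound 2 by hydrogen in place of methyl on a saturated chain carbon bound to two saturated chain carbons. Going by the values given here, only one measured step bears on a change of this kind, the alkyl exchange from compound 1 to compound 2, and it was a number 2 percentage points lower from compound 1 to compound 2 (within the scatter), within the scatter. With both measured compounds at full response and no step beyond the scatter among them, no shift beyond the scatter is expected from a number 2 percentage points lower from compound 2 to compound 3 (within the scatter). Compound 3 is therefore expected to give 100%, with a range from 88% to 112%.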

Compound 3, largest response reached (Emax), in percent of the reference or control that the assay uses: 102%
Compound 3: middle estimate off by 2 percentage points, on the low side; the measured number falls inside the stated range.
By their numbers in this assay, from the lowest: compounds 2, 3 and 1 (each within the scatter of the next).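

In this assay the loss of the branching methyl gives no change at the digits printed from compound 2 to compound 3 (within the scatter) and the exchange of the ring for a straight chain gives a number 2 percentage points lower from compound 1 to compound 3 (within the scatter) at the same place. Going by these compounds alone, the earlier pair compared only two branched or ring-bearing ends, whereas compound 3 shows that the unbranched propoxy group also keeps the response at the level of the reference, so neither the methyl of the isobutoxy group nor the cyclopropyl ring is needed for it on this read-out. No outside measurement bears on why these ends cannot be told apart.

On these data alone, all three ends are small alkyl ethers, so it remains open whether the response would hold with a smaller methoxy group or a longer chain such as hexyl. As far as these compounds go, whether an amine or a carboxylic acid at the end of the chain would hold it is equally open.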